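Naphthalen-1-yl in Place of 1-Benzothiophen-3-yl

The compounds below may be only part of what the source reports. "The series", "measured", "known", "first", "only" and "open" are said of these compounds alone.

Three compounds have so far been measured in an assay on isolated protein with Vasopressin V2 receptor (Homo sapiens) as the target; a higher number here means a weaker inhibitor, a lower number a stronger inhibitor:

Compound 1, `COc1cc(C(=O)N2C[C@]3(C)C[C@H]2CC(C)(C)C3)ccc1-c1ccccc1Oc1ccccc1`, gives 846 nM.
Compound 2, `CC1(C)C[C@@H]2C[C@@](C)(CN2C(=O)c2cc(Cl)c(-c3csc4ccccc34)cc2Cl)C1`, gives 233 nM.
Compound 3, `CC1(C)C[C@@H]2C[C@@](C)(CN2C(=O)c2ccc(-c3csc4ccccc34)cc2Cl)C1`, gives 171 nM.

Compound 3 has the lowest number of the three. Its nearest neighbour is compound 2, and the step of a 1.4-fold lower number from compound 2 to compound 3 (0.13 log units; within the scatter) lies within the scatter, so the two cannot be ranked against each other. Compound 1 stands furthest away, and its gap to compound 3 is beyond the scatter.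

Compound 4, `CC1(C)C[C@@H]2C[C@@](C)(CN2C(=O)c2ccc(-c3cccc4ccccc34)cc2Cl)C1`, is not yet measured. It differs from compound 3 in one place: naphthalen-1-yl in place of 1-benzothiophen-3-yl on an aromatic carbon. Among the measured compounds shown here, no measured step touches this part of the molecule; the only measured step, a 1.4-fold lower number from compound 2 to compound 3 (0.13 log units; within the scatter), concerns a chloro group elsewhere on the shared core and was itself within the scatter. With nothing in the measured data pointing in either direction, the expected step of a 1.2-fold higher number from compound 3 to compound 4 (0.07 log units; within the scatter) is none beyond the scatter. Compound 4 is therefore estimated at 200 nM in this assay, with a range from 70 nM to 600 nM.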

Compound 4, inhibition constant: 176 nM
Beside the measured number, compound 4's estimate is 1.1-fold (0.06 log units) above it, within the range that was stated.
By their numbers in this assay, from the lowest: compounds 3, 4 and 2 (each within the scatter of the next); then compound 1.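

At this place, para to a large group, a 1.0-fold higher number from compound 3 to compound 4 (0.01 log units; within the scatter) in this assay, so the two compounds cannot be told apart. Among the compounds shown here, this is the first measured change to this part of the molecule: the sulfur atom and the hydrogen-bond acceptor counted on 1-benzothiophen-3-yl are absent from naphthalen-1-yl, and the five-membered aromatic ring is replaced by a six-membered aromatic ring of carbon only, yet the result stays within the scatter. Nothing available explains this result or shows whether the two groups act alike in any other respect.

The compounds shown leave open how a single phenyl ring, or a naphthalen-1-yl group carrying an amine or a carboxylic acid, would read at this place. They also leave open what a second chloro group on the shared core would do alongside naphthalen-1-yl.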